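Swapping 4-nitrophenyl for pyridin-4-yl on the shared core

The source may report more compounds than this note shows. Statements on the series, on what has been measured and on what is new or still open speak of the compounds shown alone.

Values measured in a functional assay on HL-60 cells (Homo sapiens) for cytotoxicity, read by WST assay, with a stated time of 48 h; a higher number here means a weaker inhibitor, a lower number a stronger inhibitor
- Compound 1 `O[C@@H](c1ccccc1)[C@H]1CO[C@H](c2ccccc2)[C@@H](C/C=C/c2ccccn2)C1` gives 36400 nM
- Compound 2 `Cc1ccc(/C=C/C[C@H]2C[C@@H]([C@@H](O)c3ccccc3)CO[C@@H]2c2ccccc2)cc1C` gives 9880 nM
- Compound 3 `O=[N+]([O-])c1ccc(/C=C/C[C@H]2C[C@@H]([C@@H](O)c3ccccc3)CO[C@@H]2c2ccccc2)cc1` gives 4880 nM

These compounds share one core and differ only in the group on a double-bonded chain carbon bound to a double-bonded chain carbon. Compound 3 has the lowest of the three numbers, with a 2.0-fold lower number from compound 2 to compound 3 (0.31 log units; beyond the scatter) as the gap to its nearest neighbour.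

Compound 4 `O[C@@H](c1ccccc1)[C@H]1CO[C@H](c2ccccc2)[C@@H](C/C=C/c2ccncc2)C1` has not yet been measured. It carries pyridin-4-yl in place of 4-nitrophenyl in that same place, and the full difference is pyridin-4-yl in place of 4-nitrophenyl on a double-bonded chain carbon bound to a double-bonded chain carbon in this one group.

The most relevant measured step is a 7.5-fold lower number from compound 1 to compound 3 (0.87 log units; beyond the scatter), where 4-nitrophenyl took the place of pyridin-2-yl. Another is a 3.7-fold lower number from compound 1 to compound 2 (0.57 log units; beyond the scatter), where 3,4-dimethylphenyl took that place. For the measured compounds named here, no measurement yet compares pyridin-4-yl with pyridin-2-yl, so compound 1 is only an approximate guide. Even so, reversing the first of these steps points to a weaker inhibitor, with a modest step beyond the scatter.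

The expected change in this assay is a 5.7-fold higher number from compound 3 to compound 4 (0.76 log units; beyond the scatter) as the estimated step. For compound 4 the estimated value is 28000 nM, with an expected range from 11000 nM to 60000 nM for a single measurement.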

Compound 4, half-maximal inhibitory concentration: > 100000 nM
Compound 4: only a limit was reported; the forecaster's own chance of this, stated with the estimate: 15%; at least 3.5-fold (0.55 log units) between middle value and limit.
By their numbers in this assay, from the lowest: compound 3; then compound 2; then compound 1. At a limit, above all of these: compound 4.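

In this assay, compound 4 is reported only as a limit of the assay, not as a number: the limit of > 100000 nM in this assay, at which 1 of the 4 values shown sits. Against the groups whose aromatic ring is made of carbon only, the change is clear: pyridin-4-yl in place of 4-nitrophenyl gives an at least 20-fold higher number from compound 3 to compound 4 (1.31 log units; beyond the scatter), and pyridin-4-yl in place of 3,4-dimethylphenyl gives an at least 10-fold higher number from compound 2 to compound 4 (1.00 log units; beyond the scatter). For the compounds shown here, the earlier compounds held only one ring with a nitrogen atom, whereas the step of an at least 2.7-fold higher number from compound 1 to compound 4 (0.43 log units; beyond the scatter) now shows that pyridin-4-yl and pyridin-2-yl are not interchangeable on this double-bonded chain carbon, with pyridin-2-yl giving the lower number of these two.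

How far compound 4 truly lies past its limit stays open, so the full size of these steps is unknown, and the compounds shown do not explain why the groups rank in this order. Going by these compounds, it also remains open whether the order holds beyond these four groups, which pyridin-3-yl, plain phenyl or 4-methoxyphenyl in the same place would help to test.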